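The compounds below may be only part of what the source reports. "The series", "measured", "known", "first", "only" and "open" are said of these compounds alone.

Values in a functional assay on cells for antagonist activity at C-C chemokine receptor type 4 (Homo sapiens), read by GTPgammaS binding (a higher number here means a weaker inhibitor, a lower number a stronger inhibitor), for the three measured compounds:

compound 1, `COCCOc1nn(C)c2ncnc(NS(=O)(=O)c3cccc(Cl)c3Cl)c12`: 794 nM
compound 2, `COCCn1nc(OC)c2c(NS(=O)(=O)c3cccc(Cl)c3Cl)ncnc21`: 316 nM
compound 3, `COc1nn(C)c2nc(C)nc(NS(=O)(=O)c3cccc(Cl)c3Cl)c12`: 631 nM

Compound 3 holds the second highest of the three numbers in this assay. Compound 1 sits within the scatter of it, as does compound 2, so the three measured values do not separate in any firm order.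

Compound 4, `COc1nn(C)c2nc(N)nc(NS(=O)(=O)c3cccc(Cl)c3Cl)c12`, differs from compound 3 in one place: amino in place of methyl on an aromatic carbon. Among the compounds with values here, no measured pair shows this change, so its effect in this assay is not known from the data; the working expectation is a step of no more than the usual scatter, in either direction. Compound 4 is therefore estimated at 500 nM in this assay, with a range of 150 nM to 1600 nM. This estimate means a step of a 1.3-fold lower number from compound 3 to compound 4 (0.10 log units; within the scatter), expected to stay within the scatter.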

Compound 4, half-maximal inhibitory concentration: 316 nM
Beside the measured number, compound 4's estimate is 1.6-fold (0.20 log units) above it; the range from low to high includes it.
By their numbers in this assay, from the lowest: compounds 2, 4, 3 and 1 (each within the scatter of the next, the first and the last beyond it).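

In this assay the series gains its first single-place comparison, a 2.0-fold lower number from compound 3 to compound 4 (0.30 log units; within the scatter), at the aromatic carbon between two ring nitrogen atoms. Amino in place of methyl adds a hydrogen-bond donor and a hydrogen-bond acceptor by count, yet the step stays within the scatter. No measurement at hand bears on the origin of this step.

Still open, on these data alone, is whether a dimethylamino group, a carboxylic acid or a longer alkyl chain at this position would give a step beyond the scatter. One pair also cannot show whether the same change would give a similar step on the other substitution patterns of the core.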